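This account rests on a few compounds, and the source may have more. Where it says the series, first, only, none or still open, it means among the compounds named here.

Compound 1 `CN[C@@H]1CC[C@@H](c2ccc(F)cc2)c2ccccc21`: 220 nM
Compound 2 `CCCCOc1ccc([C@@H]2CC[C@@H](NC)c3ccccc32)cc1`: 6800 nM
Compound 3 `CN[C@@H]1CC[C@@H](c2ccc(Oc3ccccc3)cc2)c2ccccc21`: 8400 nM

Of the compounds shown here, three share one core and have been tested in a functional assay on striatum for inhibition of sodium-dependent dopamine transporter (Rattus norvegicus); on this read-out higher numbers stand for weaker inhibition and lower numbers for stronger inhibition. Compound 1 gives the lowest number of the three: the step from it to compound 2 is a 31-fold higher number from compound 1 to compound 2 (1.49 log units; beyond the scatter), and the step to compound 3 is a 38-fold higher number from compound 1 to compound 3 (1.58 log units; beyond the scatter). Between compound 2 and compound 3 the step is a 1.2-fold higher number from compound 2 to compound 3 (0.09 log units; within the scatter), so those two cannot be told apart.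

Compound 4 `CN[C@H]1CC[C@@H](c2ccc(F)cc2)c2ccccc21` is now to be measured in this assay. Compared with compound 1, (the two compounds have the same atoms and bonds and differ only in configuration as drawn: 1 of 2 stereo elements differ; a stereocentre at a saturated ring carbon is drawn R in compound 1 and S in compound 4); nothing leaves and nothing enters. Within the data shown here, none of the measured steps touches configuration: the two large steps from compound 1 swap the fluoro for butoxy or phenoxy, and the small step swaps butyl for phenyl on an oxygen. They give no direct guide to the size or direction of a change in configuration alone. Such a change can alter activity considerably, and the expectation here is a moderate weakening, with wide uncertainty: the step from compound 1 to compound 4 is estimated at a 4.1-fold higher number from compound 1 to compound 4 (0.61 log units; beyond the scatter). Compound 4 is therefore expected to give about 900 nM, in a range from 150 nM to 6000 nM.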

Compound 4, half-maximal inhibitory concentration: 4700 nM
Compound 4: middle estimate off by 5.2-fold (0.72 log units), on the low side, and the stated range covers the measured number.
By their numbers in this assay, from the lowest: compound 1; then compounds 4, 2 and 3 (each within the scatter of the next).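

The new pair shows that this saturated ring carbon is sensitive to configuration alone: in this assay, a 21-fold higher number from compound 1 to compound 4 (1.33 log units; beyond the scatter). Until now, large steps had appeared only when the fluoro was swapped for butoxy or phenoxy, whereas here every atom and bond stays the same and only the stereocentre goes from R in compound 1 to S in compound 4. The large step can therefore be assigned to that one inversion, because nothing else separates the two structures: the fact that compounds 1 and 4 differ only in the configuration as drawn

Among these compounds, this is still a single pair, with fluoro as the only aromatic group tested in both configurations, so it does not show whether the R form would also give the lower number with butoxy, phenoxy or a group such as chloro or trifluoromethyl on the aromatic ring. On these data alone, the effect of inverting the other stereocentre, alone or together with this one, also remains open, as does the effect of replacing the methyl on the nitrogen with a longer chain such as ethyl in either configuration.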